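The source may report more compounds than this note shows. Statements on the series, on what has been measured and on what is new or still open speak of the compounds shown alone.

Series notes. Compound 1 `CC1(C)C=Cc2c(ccc(C(=O)/C=C/c3ccc(Cl)cc3)c2O)O1`, compound 2 `CC1(C)C=Cc2c(ccc(C(=O)/C=C/c3ccc(F)c(F)c3)c2O)O1` and compound 3 `CC1(C)C=Cc2c(ccc(C(=O)/C=C/c3ccc(Cl)cc3Cl)c2O)O1` share one core and differ only in the aryl carried on the chain. In an ADME assay on Vero cells (Chlorocebus sabaeus) for cytotoxicity, read by MTT assay, with a stated time of 72 h (a lower number here means that less compound is tolerated, a higher number that more compound is tolerated), compound 1 gives 92200 nM, compound 2 gives 146000 nM and compound 3 gives 131000 nM. Compound 3 thus stands second highest of the three numbers, nearest to compound 2 and furthest from compound 1, both gaps within the scatter. The measured steps are a 1.6-fold higher number from compound 1 to compound 2 (0.20 log units; within the scatter), a 1.4-fold higher number from compound 1 to compound 3 (0.15 log units; within the scatter) and a 1.1-fold lower number from compound 2 to compound 3 (0.05 log units; within the scatter); every one of them falls within the scatter. Compound 4 `CC1(C)C=Cc2c(ccc(C(=O)/C=C/c3cccnc3)c2O)O1` has not yet been measured. Its change from compound 3 is pyridin-3-yl in place of 2,4-dichlorophenyl on a double-bonded chain carbon bound to a double-bonded chain carbon. The two aryl swaps already measured bear most directly on this step, and neither moved the number beyond the scatter, nor did the added chloro. No result in this assay speaks to a pyridin-3-yl in this position, so the expectation rests on the flat record of the aryl changes so far. A step from compound 3 to compound 4 of a 1.0-fold lower number from compound 3 to compound 4 (0.00 log units; within the scatter) is expected, that is none beyond the scatter. Compound 4 is therefore estimated at 130000 nM, with a range from 60000 nM to 280000 nM, the range kept wide since the entering group lies outside anything measured here.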

Compound 4, half-maximal cytotoxic concentration: 8600 nM
For compound 4 the middle estimate is 15-fold (1.18 log units) above the measured one; measured number below the stated range.
By their numbers in this assay, from the lowest: compound 4; then compounds 1, 3 and 2 (each within the scatter of the next).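

The aryl position on the chain is not silent in this assay after all: the swaps among chloro- and fluoro-substituted phenyl groups left the number within the scatter, while a ring nitrogen brings a large drop in the concentration tolerated. Pyridin-3-yl on a double-bonded chain carbon bound to a double-bonded chain carbon gives a 15-fold lower number from compound 3 to compound 4 (1.18 log units; beyond the scatter) and a 17-fold lower number from compound 2 to compound 4 (1.23 log units; beyond the scatter) and an 11-fold lower number from compound 1 to compound 4 (1.03 log units; beyond the scatter) and so sets compound 4 apart from the three halogen-bearing compounds, all of which stay within the scatter of one another. Nothing available accounts for this drop.

In each of these steps the halogens leave and the ring nitrogen with its hydrogen-bond acceptor enters in a single change, so the compounds shown cannot tell whether the loss of halogen or the gain of nitrogen carries the step. Unsubstituted phenyl would separate the two, while pyridin-2-yl and pyridin-4-yl would show whether the step depends on where the nitrogen stands in the ring.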